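Swapping one phenyl group in compound 3

The compounds below may be only part of what the source reports. "The series", "measured", "known", "first", "only" and "open" are said of these compounds alone.

Values measured in a functional assay on MCF7 cells (Homo sapiens) for inhibition, read by MTT assay, with a stated time of 3 days (on this read-out lower numbers stand for stronger inhibition and higher numbers for weaker inhibition), follow.
- Compound 1 (`C=CCOc1cc(/C=C\c2cc(OC)c(OC)c(OC)c2)ccc1OC`) gives 12000 nM
- Compound 2 (`COc1ccc(/C=C\c2cc(OC)c(OC)c(OC)c2)cc1OCc1ccccc1`) gives 59000 nM
- Compound 3 (`COc1ccccc1/C=C/CCCOc1cc(/C=C\c2cc(OC)c(OC)c(OC)c2)ccc1OC`) gives 21000 nM

The data show a 1.8-fold higher number from compound 1 to compound 3 (0.24 log units; within the scatter) and a 2.8-fold lower number from compound 2 to compound 3 (0.45 log units; beyond the scatter), so compound 3 has no real gap to one neighbour and a modest gap to the other.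

Compound 4 (`COCOc1ccc(/C=C/CCCOc2cc(/C=C\c3cc(OC)c(OC)c(OC)c3)ccc2OC)cc1`) carries 4-(methoxymethoxy)phenyl in place of 2-methoxyphenyl, on a double-bonded chain carbon bound to a double-bonded chain carbon (4-(methoxymethoxy)phenyl in place of 2-methoxyphenyl on a double-bonded chain carbon bound to a double-bonded chain carbon). For the measured compounds named here, no measured step tests this exchange directly. The three steps in the same side chain bear on it only loosely, and the largest, a 4.9-fold higher number from compound 1 to compound 2 (0.69 log units; beyond the scatter), was modest. For compound 4 the expected step in this assay is a 1.1-fold higher number from compound 3 to compound 4 (0.06 log units; within the scatter), which means no clear change. Compound 4 is estimated at 24000 nM, within an expected range from 10000 nM to 55000 nM.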

Compound 4, half-maximal inhibitory concentration: 42000 nM
Compound 4: middle estimate off by 1.8-fold (0.24 log units), on the low side, and the stated range covers the measured number.
By their numbers in this assay, from the lowest: compounds 1, 3, 4 and 2 (each within the scatter of the next, the first and the last beyond it).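

In this assay, 4-(methoxymethoxy)phenyl in place of 2-methoxyphenyl on a double-bonded chain carbon gives a 2.0-fold higher number from compound 3 to compound 4 (0.30 log units; within the scatter), so the two compounds cannot be told apart. The earlier steps shown here replaced the whole group on the oxygen, whereas this one keeps the chain and changes only the aromatic group it carries, and the larger group brings no clear difference. Nothing measured here offers an explanation for this result. From the compounds shown here alone, what an amine or a carboxylic acid on that aromatic ring would do remains open.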